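Cytotoxicity on L6 Cells: From Compound 3 to Compound 4

This account rests on a few compounds, and the source may have more. Where it says the series, first, only, none or still open, it means among the compounds named here.

Compound 1 `COc1cc(NC(C)CCCNC(=O)/C=C/c2ccc(C(F)(F)F)cc2)c2ncccc2c1`: 160000 nM
Compound 2 `COc1cc(NC(C)CCCNC(=O)NC2CCCC2)c2ncccc2c1`: "not determined" (no result reported)
Compound 3 `COc1cc(NC(C)CCCNC(=O)NNC(=O)/C=C/c2ccc(C(F)(F)F)cc2)c2ncccc2c1`: 28300 nM

Of the compounds shown here, three of the shared core have been tested in an ADME assay on L6 cells (Rattus norvegicus) for cytotoxicity, read by resazurin assay, with a stated time of 70 h; on this read-out lower numbers stand for stronger inhibition and higher numbers for weaker inhibition. Compound 1 gives 160000 nM, compound 2 gives "not determined" (no result reported) and compound 3 gives 28300 nM. Of the two numbers reported, compound 3 has the lower one, and its gap to compound 1 lies beyond the scatter.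

Compound 4 `COc1cc(NC(C)CCCNC(=O)NNC(=O)Nc2ccc(C(F)(F)F)cc2)c2ncccc2c1` differs from compound 3 in one place: (4-(trifluoromethyl)phenyl)amino in place of 2-(4-(trifluoromethyl)phenyl)ethenyl on a carbonyl carbon. The pair leaves the 2-(4-(trifluoromethyl)phenyl)ethenyl group behind and sets a (4-(trifluoromethyl)phenyl)amino group on the same carbonyl carbon, whose other neighbour is an amide-type nitrogen.

Within the data shown here, no measured pair shows this change, so the account rests on compound 3 alone. Compound 4 is expected to show a step of a 2.1-fold higher number from compound 3 to compound 4 (0.33 log units; beyond the scatter), that is a moderate rise in the number, though a result within the scatter would not surprise. Compound 4 is accordingly estimated at 60000 nM, with a range from 20000 nM to 180000 nM.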

Compound 4, half-maximal inhibitory concentration: 14900 nM
The estimate for compound 4 lay 4.0-fold (0.60 log units) above the measured number; measured number below the stated range.
By their numbers in this assay, from the lowest: compounds 4 and 3 (each within the scatter of the next); then compound 1.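

In this assay, among these compounds, (4-(trifluoromethyl)phenyl)amino in place of 2-(4-(trifluoromethyl)phenyl)ethenyl on a carbonyl carbon gives the first step between compounds that differ in one place (a 1.9-fold lower number from compound 3 to compound 4 (0.28 log units; within the scatter)). At this position, then, the exchange cannot be told apart from the usual scatter of repeated measurements, even though the entering group carries a hydrogen-bond donor and the group that leaves carries a double bond outside aromatic rings. No measurement is at hand that could account for this result.

The compounds shown leave open whether a carboxylic acid or an amine in place of the trifluoromethyl group, or a longer chain on the carbonyl carbon, would move the number beyond the scatter. They also leave open whether the same exchange would read alike on compound 1.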